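Notes on a small cytotoxicity series, compound 4 pending

The source may hold more compounds than are shown below. What is called first, only, known or untested is meant among the compounds shown, and "the series" means these compounds.

Measured so far in a functional assay on MGC-803 cells (Homo sapiens) for cytotoxicity, read by MTT assay, with a stated time of 72 h; a lower number here means a stronger inhibitor, a higher number a weaker inhibitor:
compound 1, `O=C(CCl)Nc1ccc(C(=O)/C=C/c2ccccc2)cc1`, 6940 nM
compound 2, `O=C(CCl)Nc1ccc(C(=O)/C=C/c2ccc(Br)cc2)cc1`, 6050 nM
compound 3, `O=C(CSC(=S)N[C@H]1CCOC1=O)Nc1ccc(C(=O)/C=C/c2ccccc2)cc1`, 24800 nM

Compound 1 and compound 2 differ by bromo in place of hydrogen on an aromatic carbon, which gave a 1.1-fold lower number from compound 1 to compound 2 (0.06 log units; within the scatter). Compound 3 carries a different tail: relative to compound 1 it has a group of 10 heavy atoms (5 carbon, 1 nitrogen, 2 oxygen, 2 sulfur; one five-membered non-aromatic ring with 1 hetero atom) in place of one chlorine atom, on a saturated chain carbon bound to a carbonyl carbon, and that gave a 3.6-fold higher number from compound 1 to compound 3 (0.55 log units; beyond the scatter).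

Compound 4, `O=C(CSC(=S)N[C@H]1CCOC1=O)Nc1ccc(C(=O)/C=C/c2ccc(Br)cc2)cc1`, awaits measurement. It differs from compound 3 by bromo in place of hydrogen on an aromatic carbon, the same change as between compound 1 and compound 2, at the same place, now on the core of compound 3. Because a 1.1-fold lower number from compound 1 to compound 2 (0.06 log units; within the scatter), the step in this assay is expected to be about as small, a 1.1-fold lower number from compound 3 to compound 4 (0.05 log units; within the scatter). Compound 4 is therefore estimated at 22000 nM, with a likely range from 9000 nM to 55000 nM; this rests on two measured steps only, and the tail of compound 3 has not been paired with this change before.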

Compound 4, half-maximal inhibitory concentration: 19600 nM
The estimate for compound 4 lay 1.1-fold (0.05 log units) above the measured number, and the stated range covers the measured number.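

In this assay, bromo in place of hydrogen gives a 1.3-fold lower number from compound 3 to compound 4 (0.10 log units; within the scatter), and this step carries over between the two cores: the same change on two cores in this assay, a 1.1-fold lower number (0.06 log units; within the scatter) from compound 1 to compound 2 and a 1.3-fold lower number (0.10 log units; within the scatter) from compound 3 to compound 4, 1.1-fold (0.04 log units) apart, within the scatter of two such steps

The exchange of the chlorine atom for the larger group gives a 3.2-fold higher number from compound 2 to compound 4 (0.51 log units; beyond the scatter), and it also carries over whether the phenyl or the 4-bromophenyl is present: the same change on two cores in this assay, a 3.6-fold higher number (0.55 log units; beyond the scatter) from compound 1 to compound 3 and a 3.2-fold higher number (0.51 log units; beyond the scatter) from compound 2 to compound 4, 1.1-fold (0.04 log units) apart, within the scatter of two such steps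

The two changes therefore combine without a detectable interaction across these four compounds, but the bromo step is itself within the scatter, so this shows no gain from bromo and says nothing about other changes or other cores.

Open, as far as these compounds go, is whether an amine or a methoxy group in place of the bromo would give a step of similar size on both cores. Also open, from the compounds shown here alone, is whether a carboxylic acid or a longer chain in place of the chlorine atom would carry over in the same way.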